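A few compounds are considered here, and "the series" means these few. Any claim that something is new, unique, unknown or untested is made for them only; others in the source may bear on it.

The series shares one core, seen in compound 1 `CCNc1cccnc1N1CCN(C(=O)C2(C)CCc3c(C)c(O)c(C)c(C)c3O2)CC1`, compound 2 `Cc1c(C)c2c(c(C)c1O)CCC(C)(C(=O)Nc1ccncc1)O2` and compound 3 `COc1ccccc1N1CCN(CC2(C)CCc3c(C)c(O)c(C)c(C)c3O2)CC1`, each carrying a different group at the amide or amine end. All three were tested in a functional assay (brain) for inhibition, with Rattus norvegicus as the target; a lower number here means a stronger inhibitor, a higher number a weaker inhibitor. Compound 1 gives 12000 nM, compound 2 gives 2300 nM, and compound 3 gives 1000 nM. Compound 3 thus stands lowest of the three numbers: compound 2 is the nearest, its number higher by a margin beyond the scatter, and compound 1 is the furthest, also beyond the scatter. Going by the values given here, on these numbers compound 3 is the strongest inhibitor of the set, though the three differ in more than one place and no single step between them can be isolated.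

Compound 4 `COc1ccc(N2CCN(CC3(C)CCc4c(C)c(O)c(C)c(C)c4O3)CC2)cc1` has the same atoms as compound 3, joined differently: 4-methoxyphenyl in place of 2-methoxyphenyl on an amine nitrogen in a ring. Among the compounds with values here, nothing measured in this set shows what this change alone does, since no pair differs only there. The expectation is a small step in this assay, if any, toward a weaker inhibitor, with a real chance that it stays within the scatter. Compound 4 is expected to give about 2000 nM, between 600 nM and 7000 nM. That estimate means a step of a 2.0-fold higher number from compound 3 to compound 4 (0.30 log units; within the scatter), expected to sit near the edge of the scatter.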

Compound 4, half-maximal inhibitory concentration: 200 nM
The estimate for compound 4 lay 10-fold (1.00 log units) above the measured number; the whole stated range lies above it.
By their numbers in this assay, from the lowest: compound 4; then compound 3; then compound 2; then compound 1.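

In this assay, going by these compounds alone, 4-methoxyphenyl in place of 2-methoxyphenyl on an amine nitrogen in a ring gives a 5.0-fold lower number from compound 3 to compound 4 (0.70 log units; beyond the scatter), and this is the first step that can be read at a single place. The group on this nitrogen therefore matters to the read-out even when its atoms stay the same: the heavy atoms, the single hydrogen-bond acceptor and the absence of net charge are identical on both sides, so none of these counts separates the pair. The data offer nothing that accounts for the size of the step.

A plain phenyl group or an ethoxyphenyl group on the same nitrogen would be needed to show whether the methoxy oxygen itself contributes, or whether the lower number comes mainly from leaving the 2-methoxyphenyl arrangement. On these data alone, it also remains open whether the same exchange would carry over to compounds with a carbonyl attached to the amine ring, as in compound 1, since that compound differs from this pair in more than one place.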